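The compounds below may be only part of what the source reports. "The series", "measured", "known", "first", "only" and "open" are said of these compounds alone.

Compound 1 `O=C(Nc1ccc(Oc2ccnc3[nH]ccc23)c(F)c1)c1nn(-c2ccc(Cl)c(F)c2)ccc1=O`: 13600 nM
Compound 2 `Cn1ccc2c(Oc3ccc(NC(=O)c4nn(-c5ccc(Cl)c(F)c5)ccc4=O)cc3F)ccnc21`: 17900 nM
Compound 3 `Cc1cc(=O)n(-c2ccccc2OC(F)(F)F)nc1C(=O)Nc1ccc(Oc2ncnc3[nH]ccc23)cc1`: 22500 nM

In a functional assay on PC-3 cells (Homo sapiens) for cytotoxicity, read by MTT assay, with a stated time of 72 h (on this read-out lower numbers stand for stronger inhibition and higher numbers for weaker inhibition), compound 1 gives 13600 nM and compound 2 gives 17900 nM. The difference between them is methyl in place of hydrogen on an aromatic nitrogen, and the step it made was a 1.3-fold higher number from compound 1 to compound 2 (0.12 log units; within the scatter). Compound 3 gives 22500 nM in this assay; the difference between the core of compound 3 and the core of compound 1 is not broken down here. Compound 4 `Cc1cc(=O)n(-c2ccccc2OC(F)(F)F)nc1C(=O)Nc1ccc(Oc2ncnc3c2ccn3C)cc1` has not yet been measured in this assay. It differs from compound 3 by methyl in place of hydrogen on an aromatic nitrogen, the same change as that from compound 1 to compound 2. Resting on a 1.3-fold higher number from compound 1 to compound 2 (0.12 log units; within the scatter), the expected step in this assay is a 1.3-fold higher number from compound 3 to compound 4 (0.11 log units; within the scatter). Compound 4 is therefore estimated at 29000 nM, with a likely range from 14000 nM to 60000 nM.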

Compound 4, half-maximal inhibitory concentration: 5160 nM
The estimate for compound 4 lay 5.6-fold (0.75 log units) above the measured number, and the stated range ends above it.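

In this assay, methyl in place of hydrogen on an aromatic nitrogen gave a 4.4-fold lower number from compound 3 to compound 4 (0.64 log units; beyond the scatter), so the step on one core did not carry over to the other: the same change on two cores in this assay, a 1.3-fold higher number (0.12 log units; within the scatter) from compound 1 to compound 2 and a 4.4-fold lower number (0.64 log units; beyond the scatter) from compound 3 to compound 4, 5.7-fold (0.76 log units) apart, beyond the scatter of two such steps In this series, then, the step measured on the core of compound 1 was a poor guide to the step on the core of compound 3. This does not show which of the several differences between those two cores sets the step apart, and two pairs give no rule for any other core.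

The compounds shown leave open how an ethyl group, or a longer chain ending in an amine, would behave on that same nitrogen. From the compounds shown here alone, whether either would follow the step seen on the core of compound 3 remains unknown.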